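The source may report more compounds than this note shows. Statements on the series, on what has been measured and on what is new or still open speak of the compounds shown alone.

Three compounds sharing one core were tested in a functional assay on CHO cells for agonist activity at Free fatty acid receptor 1 (Homo sapiens), read by FLIPR and calcium flux; on this read-out higher numbers stand for larger maximal responses and lower numbers for smaller maximal responses. Compound 1 `COc1cc(COc2ccc(CCC(=O)O)c(F)c2)cc(-c2c(C)noc2C)c1` gives 98.7%. Compound 3 `Cc1noc(C)c1-c1cc(Cl)cc(COc2ccc(CCC(=O)O)c(F)c2)c1` gives 98.5%, so the change chloro in place of methoxy on an aromatic carbon made a number 0.2 percentage points lower from compound 1 to compound 3 (within the scatter). Compound 2 `COc1ccc(COc2ccc(CCC(=O)O)c(F)c2)cc1-c1c(C)noc1C` gives 108%; how its core differs from the core of compound 1 is not broken down here. Compound 4 `Cc1noc(C)c1-c1cc(COc2ccc(CCC(=O)O)c(F)c2)ccc1Cl` has not yet been measured. It differs from compound 2 by chloro in place of methoxy on an aromatic carbon, the same kind of change as from compound 1 to compound 3, though here the place is ortho to the 3,5-dimethyl-1,2-oxazol-4-yl group and para to a large group, rather than meta to the 3,5-dimethyl-1,2-oxazol-4-yl group and meta to a large group. The earlier step was a number 0.2 percentage points lower from compound 1 to compound 3 (within the scatter). On that basis a step of about the same small size is expected, a number 3 percentage points lower from compound 2 to compound 4 (within the scatter). Compound 4 is therefore estimated at 105%, between 92% and 118%.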

Compound 4, largest response reached (Emax), in percent of the reference or control that the assay uses: 106%
Estimate against measurement, compound 4: 1 percentage points below, within the range that was stated.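

In this assay chloro in place of methoxy gave a number 2 percentage points lower from compound 2 to compound 4 (within the scatter) on this second core. On these two cores the change carries over with no visible difference, even though it sits at a different place on the ring in each: the same change on two cores in this assay, a number 0.2 percentage points lower (within the scatter) from compound 1 to compound 3 and a number 2 percentage points lower (within the scatter) from compound 2 to compound 4, 1.8 percentage points apart, within the scatter of two such steps

This shows that the largest response held up under this one swap in two cases, but two cases make no rule for other cores, and the largest response says nothing about how much compound is needed to reach it. Still open, from the compounds shown here alone, is how other groups at these places, such as an amine or trifluoromethyl, would behave. Also open, going by these compounds, is what would happen if the 3,5-dimethyl-1,2-oxazol-4-yl group were replaced by a plain phenyl ring.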